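The source may report more compounds than this note shows. Statements on the series, on what has been measured and on what is new or still open speak of the compounds shown alone.

Working notes on the series. For the measured compounds named here, in a functional assay on HEK293 cells for agonist activity at 5-hydroxytryptamine receptor 4 (Homo sapiens), read by cAMP accumulation (on this read-out lower numbers stand for an effect already at smaller amounts and higher numbers for an effect only at larger amounts of compound), compound 1 `COc1cc(N)c(Cl)cc1C(=O)NC1CCNCC1` gives 398 nM, the lowest of the three numbers measured so far. Compound 2 `COc1cc(N)c(Cl)cc1C(=O)NCCN1CCNCC1` gives 501 nM in this assay, a number within the scatter of that of compound 1, so the two cannot be ordered. Compound 3 `COc1ccc2[nH]cc(C(=O)NC3CCNCC3)c2c1`, built on a different core, gives 100000000 nM in this assay, far beyond the scatter from compound 1. Going by the values given here, no pair of measured compounds differs in a single place, so no step of any kind has been quantified in this set.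

The next compound keeps the core of compound 1 and adds a chain: compound 4 `COc1cc(N)c(Cl)cc1C(=O)NC1CCN(CCCCCCCCO)CC1` differs from compound 1 by 8-hydroxyoctyl in place of hydrogen on an amine nitrogen in a ring. Among the compounds with values here, no measured pair shows what substitution on this ring nitrogen does in this assay; the expectation below therefore rests on compound 1 alone. The step of a 3.3-fold lower number from compound 1 to compound 4 (0.52 log units; beyond the scatter) is expected to lower the number, with wide uncertainty. For compound 4 in this assay the estimate is 120 nM, within a range from 15 nM to 1000 nM.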

Compound 4, half-maximal effective concentration: 15.9 nM
Compound 4: the middle estimate sits 7.5-fold (0.88 log units) above what was measured; low and high end bracket the measured number.
By their numbers in this assay, from the lowest: compound 4; then compounds 1 and 2 (each within the scatter of the next); then compound 3.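

For the compounds shown here, on the ring nitrogen of the core of compound 1, this assay tolerates far more than hydrogen: 8-hydroxyoctyl on this amine nitrogen in a ring gives a 25-fold lower number from compound 1 to compound 4 (1.40 log units; beyond the scatter) and is the only single-place change quantified. The substituted ring nitrogen therefore does not cost activity on this read-out, and the large step runs toward a lower number even with a long chain in place. No measurement in hand bears on why the number falls.

A single step cannot separate the contribution of chain length from that of the terminal hydroxyl. Still open, on these data alone, are a shorter chain such as butyl, a plain octyl chain without the hydroxyl, and a carboxylic acid or an amine at the chain end.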